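Aryl ether variation: estimate for compound 4

The source may hold more compounds than are shown below. What is called first, only, known or untested is meant among the compounds shown, and "the series" means these compounds.

All numbers come from a functional assay on HepG2 cells (Homo sapiens) for antiproliferative activity, read by MTT assay, with a stated time of 24 h; on this read-out lower numbers stand for stronger inhibition and higher numbers for weaker inhibition.
Compound 1, `C=CCOc1ccc2c(=O)c(-c3cc(OC)c(OC)cc3OC)coc2c1`, gives 3450 nM.
Compound 2, `COc1cc(OC)c(-c2coc3cc(OCc4ccc(F)cc4)ccc3c2=O)cc1OC`, gives 1000 nM.
Compound 3, `COc1cc(OC)c(-c2coc3cc(OCc4ccc(C#N)cc4)ccc3c2=O)cc1OC`, gives 4230 nM.

Going by the values given here, compound 3 has the highest number of the three, though its step to compound 1 is within the scatter; only the step of a 4.2-fold higher number from compound 2 to compound 3 (0.63 log units; beyond the scatter) is beyond it. Compound 4, `COc1cc(OC)c(-c2coc3cc(OCc4cccc(C(F)(F)F)c4)ccc3c2=O)cc1OC`, differs from compound 3 by 3-(trifluoromethyl)phenyl in place of 4-cyanophenyl on a saturated chain carbon bound to an oxygen on an aromatic ring. Among the compounds with values here, no measured step turns a 4-cyanophenyl into a 3-(trifluoromethyl)phenyl. Within the data shown here, the steps that bear on this place are a 3.5-fold lower number from compound 1 to compound 2 (0.54 log units; beyond the scatter) and a 1.2-fold higher number from compound 1 to compound 3 (0.09 log units; within the scatter): fluoro gave the lowest number, while the nitrile did not move the number from compound 1. Lacking a closer precedent, compound 4 is expected to fall between those outcomes, a step of a 2.1-fold lower number from compound 3 to compound 4 (0.33 log units; beyond the scatter) in this assay. Compound 4 is therefore estimated at 2000 nM, with a likely range from 700 nM to 6000 nM.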

Compound 4, half-maximal inhibitory concentration: 610 nM
Compound 4: the middle estimate sits 3.3-fold (0.52 log units) above what was measured; the measured number lies below the stated range.
By their numbers in this assay, from the lowest: compounds 4 and 2 (each within the scatter of the next); then compounds 1 and 3 (each within the scatter of the next).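

At the saturated chain carbon bound to the aryl ether oxygen, 3-(trifluoromethyl)phenyl in place of 4-cyanophenyl brings a clear gain (a 6.9-fold lower number from compound 3 to compound 4 (0.84 log units; beyond the scatter)), and the same group also improves on vinyl (a 5.7-fold lower number from compound 1 to compound 4 (0.75 log units; beyond the scatter)). It stays within the scatter of 4-fluorophenyl (a 1.6-fold lower number from compound 2 to compound 4 (0.21 log units; within the scatter)), so a second aryl group now reaches that level, while 4-cyanophenyl stays with vinyl. No supporting data explain these differences.

The step to compound 4 changes both the substituent and its ring position, leaving their separate contributions unresolved. As far as these compounds go, how an amine or carboxylic acid on this aryl ring, or a longer chain, would read remains open.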